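The source may report more compounds than this note shows. Statements on the series, on what has been measured and on what is new or still open speak of the compounds shown alone.

Measured in a functional assay on HL-60 cells (Homo sapiens) for inhibition, with a stated time of 24 h; on this read-out higher numbers stand for weaker inhibition and lower numbers for stronger inhibition:
- compound 1 `CC(=O)OC[C@H]1O[C@@H](n2cc(C(F)F)c(=O)[nH]c2=O)C[C@@H]1OC(C)=O`: 83 uM
- compound 2 `CC(=O)OC[C@H]1O[C@@H](n2cc(C(F)(F)F)c(=O)[nH]c2=O)C[C@@H]1OC(C)=O`: 501 uM

Compound 2 holds the higher of the two numbers. Compound 3 `CC(=O)OC[C@H]1O[C@@H](n2cc(CF)c(=O)[nH]c2=O)C[C@@H]1OC(C)=O` has fluoromethyl in place of trifluoromethyl on an aromatic carbon. Going by the values given here, one measured step bears on this change: a 6.0-fold higher number from compound 1 to compound 2 (0.78 log units; beyond the scatter), which lies beyond the scatter and is modest. Reversing that fluoro replacement would point to a lower number, while the effect of removing a further fluoro has not been measured. The expected step is a 3.9-fold lower number from compound 2 to compound 3 (0.59 log units; beyond the scatter), of similar size. Compound 3 is estimated at 130 uM, with a range of 40 uM to 420 uM.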

Compound 3, concentration for 50% inhibition: 3470 uM
Compound 3: the middle estimate sits 27-fold (1.43 log units) below what was measured; the measured number lies above the stated range.
By their numbers in this assay, from the lowest: compound 1; then compound 2; then compound 3.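

In this assay, fluorine count on this aromatic carbon does not order the series in one direction: fluoromethyl in place of trifluoromethyl gives a 6.9-fold higher number from compound 2 to compound 3 (0.84 log units; beyond the scatter), the same direction as the step from difluoromethyl to trifluoromethyl. Going down from difluoromethyl to fluoromethyl gives a 42-fold higher number from compound 1 to compound 3 (1.62 log units; beyond the scatter), so difluoromethyl in compound 1 gives the lowest number, with both neighbours higher. Nothing available accounts for this order.

As far as these compounds go, how a plain methyl or a hydroxymethyl group on this carbon would read remains open, as does whether the order holds with free hydroxyl groups in place of the acetyl esters.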